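Chloro for Fluoro in a Bisulfite Adduct, Cytotoxicity Unchanged

The source may report more compounds than this note shows. Statements on the series, on what has been measured and on what is new or still open speak of the compounds shown alone.

In an ADME assay on Vero C1008 cells (Chlorocebus sabaeus) for cytotoxicity, read by luminescence and CellTiter-Glo, with a stated time of 24 h (a higher number here means that more compound is tolerated, a lower number that less compound is tolerated), compound 1 `O=C[C@H](C[C@@H]1CCNC1=O)NC(=O)[C@H](CC1CC1)NC(=O)OCCc1cccc(Cl)c1` reaches only a limit, reported as > 200000 nM. Compound 2 `O=C(N[C@@H](CC1CC1)C(=O)N[C@@H](C[C@@H]1CCNC1=O)C(O)S(=O)(=O)O)OCc1cccc(F)c1` likewise gives only a limit in this assay, > 200000 nM. Both readings thus sit at the limit of > 200000 nM in this assay, at which 2 of the 2 values shown sit, so compound 2 stands no different from compound 1 on the numbers shown. Compound 3 `O=C(N[C@@H](CC1CC1)C(=O)N[C@@H](C[C@@H]1CCNC1=O)C(O)S(=O)(=O)O)OCCc1cccc(Cl)c1` differs from compound 2 by 3-chlorobenzyl in place of 3-fluorophenyl on a saturated chain carbon bound to an oxygen next to a carbonyl group. Among the measured compounds shown here, with no measured step to draw on, the step from compound 2 to compound 3 is expected to be none beyond the scatter, a step that the limit leaves unreadable from compound 2 to compound 3. Compound 3 is accordingly estimated at 300000 nM, within 150000 nM to 1000000 nM, and is most likely to be reported again only as a limit.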

Compound 3, half-maximal cytotoxic concentration: > 200000 nM
Compound 3 gave a limit, no number (the forecaster's own chance of this, stated with the estimate: 85%); the middle value does not contradict the limit.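

No step can be read from compound 2 to compound 3 or from compound 1 to compound 3, since all three give only a limit: the limit of > 200000 nM in this assay, at which 3 of the 3 values shown sit.

In this assay the compounds shown leave open at what concentration any of them would become cytotoxic.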